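Swapping Fluoro for Methyl on a Carbamate Aryl Ring

The source may report more compounds than this note shows. Statements on the series, on what has been measured and on what is new or still open speak of the compounds shown alone.

Of the compounds shown here, two built around the same core have been measured so far in an ADME assay on 184B5 cells (Homo sapiens) for cytotoxicity, read by MTT assay, with a stated time of 72 h; a lower number here means a stronger inhibitor of growth, a higher number a weaker inhibitor of growth. Compound 1, with structure `N#C[Se]c1ccc(NC(=O)Oc2ccc(F)cc2)cc1`, gives 29500 nM in this assay. Compound 2, with structure `CCOC(=O)Nc1ccc([Se]C#N)cc1`, gives 18600 nM in this assay. Compound 1 has the highest of the two numbers, and compound 2 stands nearest to it, within the usual scatter, so no order between the two can be claimed.

The next compound, compound 3 with structure `Cc1ccc(OC(=O)Nc2ccc([Se]C#N)cc2)cc1`, differs from compound 1 in a single place: methyl in place of fluoro on an aromatic carbon. The change sits on an aromatic carbon of a six-membered aromatic ring of carbon only, para to a large group.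

Among the measured compounds shown here, no pair of measured compounds shows this change, so the expectation rests on compound 1 alone. The step of a 1.2-fold lower number from compound 1 to compound 3 (0.07 log units; within the scatter) is expected to be small, with no direction that stands out beyond the scatter. For compound 3 the estimate in this assay is 25000 nM, with a likely range from 10000 nM to 60000 nM.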

Compound 3, concentration for total growth inhibition: 8700 nM
Compound 3: middle estimate off by 2.9-fold (0.46 log units), on the high side; measured number outside the range, below it.
By their numbers in this assay, from the lowest: compound 3; then compounds 2 and 1 (each within the scatter of the next).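

At this one position, on an aromatic carbon of a six-membered aromatic ring of carbon only, para to a large group, the exchange of one heavy atom for another is enough to move the result: in this assay methyl in place of fluoro gives a 3.4-fold lower number from compound 1 to compound 3 (0.53 log units; beyond the scatter). The step lies beyond the scatter and is modest in size, so this carbon is a place where a small change can be read in this assay, and of this pair, the methyl compound is the stronger inhibitor of growth. No measurement shown here explains why the number falls with this swap.

Going by these compounds, it remains open whether this step belongs to methyl in particular, or whether a chlorine atom, a methoxy group, an amine or a longer chain such as ethyl on the same carbon would give a similar number, a lower one or a higher one. On these data alone, this change is also seen in one pair of compounds only, so whether it gives a step of similar size and direction on any other core is unknown.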